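The source may hold more compounds than are shown below. What is called first, only, known or untested is meant among the compounds shown, and "the series" means these compounds.

Measured so far:
Compound 1, `Cc1cc(Cl)ccc1C(=O)Nc1ccc(S(=O)(=O)Nc2ccccc2)cc1`: 123% in a functional assay on HEK293 cells for agonist activity at probable G-protein coupled receptor 27 (Homo sapiens), read by a luciferase reporter and beta-arrestin recruitment, with a stated time of 10 min; on this read-out lower numbers stand for smaller maximal responses and higher numbers for larger maximal responses
Compound 2, `N#Cc1ccc(C(=O)Nc2ccc(S(=O)(=O)Nc3ccccc3)cc2)c(F)c1`: 29% in this assay

Among the compounds with values here, compound 2 holds the lower of the two numbers, with compound 1 the only neighbour; the one measured step is a number 94 percentage points lower from compound 1 to compound 2 (beyond the scatter). Compound 3, `O=C(Nc1ccc(S(=O)(=O)Nc2ccccc2)cc1)c1ccc(I)cc1F`, differs from compound 2 by iodo in place of cyano on an aromatic carbon. That step bears on this only loosely, since it exchanged two groups at once, the halogen among them. For compound 3 a rise is expected, a number 46 percentage points higher from compound 2 to compound 3 (beyond the scatter), because of a number 94 percentage points lower from compound 1 to compound 2 (beyond the scatter) seen when the halogen-bearing compound 1 was compared. Compound 3 is estimated at 75%, range 35% to 120%.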

Compound 3, largest response reached (Emax), in percent of the reference or control that the assay uses: 36%
The estimate for compound 3 lay 39 percentage points above the measured number; the measured number falls inside the stated range.
By their numbers in this assay, from the lowest: compounds 2 and 3 (each within the scatter of the next); then compound 1.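

In this assay, iodo and cyano on this aromatic carbon, meta to the fluoro group, cannot be told apart: a number 7 percentage points higher from compound 2 to compound 3 (within the scatter). The halogen alone therefore does not separate the high and low responses in this small set, as the 2-fluoro-4-iodophenyl group still shows a number 87 percentage points lower from compound 1 to compound 3 (beyond the scatter). No measurement at hand explains this result.

Still open, going by these compounds, is whether the methyl group of compound 1, rather than the choice of halogen, carries that gap, as the two aryl groups differ in both substituents. Also open, on these data alone, is how an amine or a carboxylic acid on this same carbon would read.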